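This account rests on a few compounds, and the source may have more. Where it says the series, first, only, none or still open, it means among the compounds named here.

Compound 1 `CC1(C)[C@H]2CC[C@]1(C)N(Cc1cn(-c3cccc(C#N)c3)nn1)C(=O)C2` carries a 3-cyanophenyl on an aromatic nitrogen of its shared core. In a functional assay on A549 cells (Homo sapiens) for inhibition, read by MTT assay, with a stated time of 24 h (on this read-out higher numbers stand for weaker inhibition and lower numbers for stronger inhibition), compound 1 gives 440 nM, the highest of the three numbers measured. Compound 2 `CC1(C)[C@H]2CC[C@]1(C)N(Cc1cn(-c3ccccc3)nn1)C(=O)C2` gives 70 nM, and compound 3 `Cc1ccc(-n2cc(CN3C(=O)C[C@@H]4CC[C@@]3(C)C4(C)C)nn2)cc1` gives 400 nM. The step of a 6.3-fold lower number from compound 1 to compound 2 (0.80 log units; beyond the scatter) shows that hydrogen in place of cyano lowers the number, while a 5.7-fold higher number from compound 2 to compound 3 (0.76 log units; beyond the scatter) shows that methyl in place of hydrogen raises it again; by contrast a 1.1-fold lower number from compound 1 to compound 3 (0.04 log units; within the scatter) is within the scatter. Compound 4 `CC1(C)[C@H]2CC[C@]1(C)N(Cc1cn(-c3ccccc3O)nn1)C(=O)C2` differs from compound 1 by 2-hydroxyphenyl in place of 3-cyanophenyl on an aromatic nitrogen. A substituted phenyl, as in compound 3, has so far stayed close to compound 1 in this assay, so little movement is expected. Compound 4 is therefore estimated at 300 nM, in the range 80 nM to 1100 nM, an expected step of a 1.5-fold lower number from compound 1 to compound 4 (0.17 log units; within the scatter).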

Compound 4, half-maximal inhibitory concentration: 230 nM
Estimate against measurement, compound 4: 1.3-fold (0.12 log units) above, within the range that was stated.
By their numbers in this assay, from the lowest: compound 2; then compounds 4, 3 and 1 (each within the scatter of the next).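

With 2-hydroxyphenyl in place, a 1.9-fold lower number from compound 1 to compound 4 (0.28 log units; within the scatter) and a 1.7-fold lower number from compound 3 to compound 4 (0.24 log units; within the scatter) both stay within the scatter in this assay, while a 3.3-fold higher number from compound 2 to compound 4 (0.52 log units; beyond the scatter) lies beyond it. Nitrile, methyl and hydroxy substituents on the phenyl thus all leave their compounds apart from the plain phenyl of compound 2, even though these groups differ in kind and ring position. Nothing shown gives a reason for this. From the compounds shown here alone, whether an amine or a carboxylic acid on the phenyl would group with compound 1, compound 3 and compound 4 remains open, as does whether any substituted phenyl can match compound 2.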